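Swapping the 4-nitrophenyl group of compound 2

A few compounds are considered here, and "the series" means these few. Any claim that something is new, unique, unknown or untested is made for them only; others in the source may bear on it.

Measured in a functional assay on A549 cells (Homo sapiens) for antiproliferative activity, read by MTT assay, with a stated time of 72 h; a lower number here means a stronger inhibitor, a higher number a weaker inhibitor:
- compound 1 `O=C(N/N=C/c1ccc([N+](=O)[O-])cc1)Nc1ccc(Oc2ccnc3[nH]ccc23)c(F)c1`: 20 nM
- compound 2 `O=C(N/N=C/c1ccc([N+](=O)[O-])cc1)Nc1ccc(Oc2ccnc3[nH]ccc23)cc1`: 2100 nM

Compound 2 has the higher, weaker number of the two. Compound 3 `O=C(N/N=C/c1ccc(O)cc1Br)Nc1ccc(Oc2ccnc3[nH]ccc23)cc1` differs from it at one place: 2-bromo-4-hydroxyphenyl in place of 4-nitrophenyl on a carbon with a double bond to nitrogen. Among the measured compounds shown here, the only measured step, a 110-fold higher number from compound 1 to compound 2 (2.02 log units; beyond the scatter), is large, but it is hydrogen in place of fluoro on an aromatic carbon, at a different place, so it gives no guide here. For the measured compounds named here, no measured step covers this swap, so no direction can be drawn and no shift beyond the scatter is expected in this assay, though the uncertainty is wide. The expected change is a 1.4-fold lower number from compound 2 to compound 3 (0.15 log units; within the scatter). The estimate for compound 3 is 1500 nM, with an expected range of 200 nM to 10000 nM.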

Compound 3, half-maximal inhibitory concentration: 5080 nM
For compound 3 the middle estimate is 3.4-fold (0.53 log units) below the measured one, and the stated range covers the measured number.
By their numbers in this assay, from the lowest: compound 1; then compound 2; then compound 3.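

The swap is the first change shown on the carbon with a double bond to nitrogen, and in this assay it gives a 2.4-fold higher number from compound 2 to compound 3 (0.38 log units; beyond the scatter), so the group here does affect the number. Even so, this step is modest beside a 110-fold higher number from compound 1 to compound 2 (2.02 log units; beyond the scatter), which lies at a different place. Nothing at hand explains the shift.

Bromine and the hydroxyl enter together, so their separate shares remain open. Also open, from the compounds shown here alone, are how an amine would fare at this place and whether the swap would act alike with the fluoro of compound 1 present.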